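The source may hold more compounds than are shown below. What is called first, only, known or untested is meant among the compounds shown, and "the series" means these compounds.

The series shares one core, and the unknown lies beside a single number. Compound 1, `C=CCn1c(=O)/c(=C\c2ccc(Cl)c(Cl)c2)[nH]c(=O)/c1=C\c1ccccc1`, is reported in a functional assay on HeLa cells (Homo sapiens) for cytotoxicity, read by CCK-8 assay, with a stated time of 72 h (a lower number here means a stronger inhibitor, a higher number a weaker inhibitor), as "not active" (no number reported), so no figure stands for it. Within the data shown here, compound 2, `C=CCn1c(=O)/c(=C\c2cc(F)ccc2C)[nH]c(=O)/c1=C\c1ccccc1OC`, gives 2900 nM in this assay, and it is the only compound with a number there; compound 1 offers only an absence of activity beside it. Among the measured compounds shown here, no pair of measured compounds differs in one place, so no measured step is available to guide the next move. Compound 3, `C=CCn1c(=O)/c(=C\c2cccc(Cl)c2Cl)[nH]c(=O)/c1=C\c1ccccc1OC`, has not yet been measured and differs from compound 2 in one place: 2,3-dichlorophenyl in place of 5-fluoro-2-methylphenyl on a double-bonded chain carbon bound to an aromatic carbon. With nothing to lean on, a modest loss is expected, and the step of a 1.7-fold higher number from compound 2 to compound 3 (0.24 log units; within the scatter) is expected to sit just beyond the usual scatter. Compound 3 is estimated at 5000 nM, within a range from 1500 nM to 16000 nM.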

Compound 3, half-maximal inhibitory concentration: 1600 nM
The estimate for compound 3 lay 3.1-fold (0.49 log units) above the measured number; the range from low to high includes it.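

In this assay, among these compounds, the exchange at this position gives a 1.8-fold lower number from compound 2 to compound 3 (0.26 log units; within the scatter), the first measured step. It replaces 5-fluoro-2-methylphenyl with 2,3-dichlorophenyl on a double-bonded chain carbon bound to an aromatic carbon, and the two compounds cannot be told apart in this read-out, so this position accepts either of these two substituted phenyl groups without a change that exceeds the scatter. No measurement shown bears on why these two compounds read alike.

A single step at a single position says nothing yet about how the number would respond to a different kind of group. Going by these compounds, whether an amine or a carboxylic acid on this phenyl group would move the number beyond the scatter remains open, as does the effect of a longer chain at the same place.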